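Compound 4: a dichlorophenyl in place of methoxyphenyl

This account rests on a few compounds, and the source may have more. Where it says the series, first, only, none or still open, it means among the compounds named here.

Among the measured compounds shown here, in a functional assay on A549 cells (Homo sapiens) for cytotoxicity, read by MTT assay, with a stated time of 72 h (a lower number here means a stronger inhibitor, a higher number a weaker inhibitor), three compounds sharing one core have numbers so far. Compound 1 `CNC(=O)c1cc(Oc2ccc(C3=NNC(c4ccc(Cl)cc4Cl)C3)cc2)ccn1`, which carries 2,4-dichlorophenyl, gives 6930 nM. Compound 2 `CNC(=O)c1cc(Oc2ccc(C3=NNC(c4ccc(C#N)cc4)C3)cc2)ccn1`, with 4-cyanophenyl, gives 17400 nM. Compound 3 `CNC(=O)c1cc(Oc2ccc(C3=NNC(c4ccc(OC)cc4)C3)cc2)ccn1`, with 4-methoxyphenyl, gives 13100 nM. Compound 3 stands close to both others, as shown by a 1.3-fold lower number from compound 2 to compound 3 (0.12 log units; within the scatter) and by a 1.9-fold higher number from compound 1 to compound 3 (0.28 log units; within the scatter). For the measured compounds named here, the only step that clears the scatter is a 2.5-fold higher number from compound 1 to compound 2 (0.40 log units; beyond the scatter).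

Compound 4 `CNC(=O)c1cc(Oc2ccc(C3=NNC(c4ccc(Cl)c(Cl)c4)C3)cc2)ccn1` has not yet been measured. It departs from compound 3 at a single place, with 3,4-dichlorophenyl in place of 4-methoxyphenyl on a saturated ring carbon. Going by the values given here, the nearest guide is compound 1, the only measured compound with a dichlorophenyl group, and its link to compound 3 is a 1.9-fold higher number from compound 1 to compound 3 (0.28 log units; within the scatter). Among the compounds with values here, the chlorines of compound 1 are arranged differently, however, and no measured pair compares the two dichlorophenyl groups directly. A small move towards the number of compound 1 is therefore expected, but not one that clearly leaves the scatter. The expected step is a 1.6-fold lower number from compound 3 to compound 4 (0.21 log units; within the scatter). For compound 4 the estimated value is 8000 nM, with an expected range from 4000 nM to 16000 nM.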

Compound 4, half-maximal inhibitory concentration: 10700 nM
The estimate for compound 4 lay 1.3-fold (0.13 log units) below the measured number, and the stated range covers the measured number.
By their numbers in this assay, from the lowest: compounds 1, 4, 3 and 2 (each within the scatter of the next, the first and the last beyond it).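

In this assay, 3,4-dichlorophenyl on the saturated ring carbon gives a 1.2-fold lower number from compound 3 to compound 4 (0.09 log units; within the scatter) and a 1.6-fold lower number from compound 2 to compound 4 (0.21 log units; within the scatter), so this group cannot be told apart from either 4-methoxyphenyl or 4-cyanophenyl at this position. Among the compounds shown here, the first direct comparison of two chlorine arrangements gives a 1.5-fold higher number from compound 1 to compound 4 (0.19 log units; within the scatter), which shows that the change from 2,4-dichlorophenyl to 3,4-dichlorophenyl leaves the number within the scatter, and so the presence of two chlorines alone does not set compound 4 apart from the compounds without chlorine. Nothing available on these compounds accounts for these small differences.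

Going by these compounds, the four groups at this position are all substituted phenyl rings, so it remains open whether an amine or a carboxylic acid on that ring, or a longer chain in its place, would move the number clearly beyond the scatter. On these data alone, the rest of the shared core is the same in all four compounds, so the effect of a change elsewhere, for instance at the methyl group of the amide, also remains open.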